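The source may hold more compounds than are shown below. What is called first, only, known or untested is meant among the compounds shown, and "the series" means these compounds.

Measured in a physicochemical assay for lipophilicity, at pH 7.4; on this read-out lower numbers stand for lower lipophilicity and higher numbers for higher lipophilicity:
- compound 1 `COc1cc(-c2nnc3n2CCCCC3c2ccc(Cl)c(Cl)c2)ccc1-c1cnc(C)o1` gives 3.5
- compound 2 `COc1cc(-c2nnc3n2CCCC3c2ccc(Cl)cc2)ccc1-c1cnc(C)o1` gives 2.8
- compound 3 `COc1cc(-c2nnc3n2CCCC3c2ccc(C(F)(F)F)cc2)ccc1-c1cnc(C)o1` gives 2.9

Among these three, compound 3 stands within the scatter of compound 2 and well short of compound 1, which is the only one of the three set apart beyond the scatter from compound 3.

The next compound is compound 4 `COc1cc(-c2nnc3n2CCCC3c2ccccc2C(F)(F)F)ccc1-c1cnc(C)o1`, which has the same atoms as compound 3, joined differently. The change is 2-(trifluoromethyl)phenyl in place of 4-(trifluoromethyl)phenyl on a saturated ring carbon and it sits on a saturated ring carbon, two ring bonds from the ring nitrogen.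

Going by the values given here, only one measured step bears on this, and only indirectly. Trifluoromethyl in place of chloro on an aromatic carbon gave a number 0.10 log units higher from compound 2 to compound 3 (within the scatter) and so changed little in this assay for a swap of group. Compound 1 differs from the others in more than one place and offers no clean comparison. Among the compounds with values here, no measured step moves a group around the aromatic ring, so the direction of any shift cannot be read from these data, and a wider range is warranted.

No step beyond the scatter is therefore expected, and the estimate amounts to a number 0.10 log units lower from compound 3 to compound 4 (within the scatter) as a small expected change. For compound 4 the expected value is 2.8 within an estimated range of 2.4 to 3.2 in this measurement.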

Compound 4, distribution coefficient: 3
Compound 4: middle estimate off by 0.20 log units, on the low side; low and high end bracket the measured number.
By their numbers in this assay, from the lowest: compounds 2, 3 and 4 (each within the scatter of the next); then compound 1.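

Taking 2-(trifluoromethyl)phenyl in place of 4-(trifluoromethyl)phenyl on the saturated ring carbon, two ring bonds from the ring nitrogen, gives in this assay a number 0.10 log units higher from compound 3 to compound 4 (within the scatter), and this is the first measured step in which the same group changes its place on the aromatic ring rather than being exchanged for another. Changing the group and its place together, with 2-(trifluoromethyl)phenyl in place of 4-chlorophenyl, gives a number 0.20 log units higher from compound 2 to compound 4 (within the scatter), so neither kind of change at this position has so far produced a step beyond the scatter, and compound 2, compound 3 and compound 4 cannot be told apart on this read-out. No measurement at hand accounts for this result.

Compound 1 differs from these three compounds in more than one place, so the compounds shown do not say how much of its separate standing belongs to any one of those differences. They also leave open whether this position stays as unresponsive when the aromatic ring carries an amine or a carboxylic acid instead of trifluoromethyl or chloro, since all three of these substituents leave the ring without such a group.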